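The source may report more compounds than this note shows. Statements on the series, on what has been measured and on what is new or still open speak of the compounds shown alone.

Compound 3 `CN1CCN(c2ccc(Nc3nc(-c4cccc(NC(=O)c5ccc(C(F)(F)F)cc5)c4)sc3C(N)=O)cc2)CC1` is the reference point of the series. In a functional assay on Ramos cells (Homo sapiens) for antiproliferative activity, read by CCK-8 assay, with a stated time of 72 h, tested at 40 uM (on this read-out higher numbers stand for more inhibition at the one concentration tested (going by the name of the read-out) and lower numbers for less inhibition), compound 3 gives 97.8%, the highest of the three numbers to hand; compound 2 `CN1CCN(c2ccc(Nc3nc(-c4cccc(NC(=O)c5ccccc5F)c4)sc3C(=O)O)cc2)CC1` gives 93.4%, which lies within the scatter of compound 3, and compound 1 `CCOC(=O)c1sc(-c2cccc(NC(=O)c3ccc(C(F)(F)F)cc3)c2)nc1Nc1ccc(N2CCN(C)CC2)cc1` gives 18.4%, far below both. Among the compounds with values here, the only single-change step measured is a number 79.4 percentage points higher from compound 1 to compound 3 (beyond the scatter), which concerns the amino in place of ethoxy on a carbonyl carbon and not the aryl amide end of the molecule.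

Compound 4 `CN1CCN(c2ccc(Nc3nc(-c4cccc(NC(=O)c5cccc(F)c5)c4)sc3C(N)=O)cc2)CC1` differs from compound 3 by 3-fluorophenyl in place of 4-(trifluoromethyl)phenyl on a carbonyl carbon. Within the data shown here, no measured step changes this group alone. Compound 2 carries a fluorophenyl on its amide carbonyl together with another group on the other carbonyl carbon, and its value sits within the scatter of compound 3, so nothing seen points to a large drop on this side. The expected step is therefore a number 5.8 percentage points lower from compound 3 to compound 4 (within the scatter), none beyond the scatter. Compound 4 is estimated at 92%, between 72% and 99% in this assay.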

Compound 4, a percentage reported as inhibition, at one concentration (the size of the read-out at that concentration, not a potency): 16.2%
Compound 4: the middle estimate sits 75.8 percentage points above what was measured; measured number below the stated range.
By their numbers in this assay, from the lowest: compounds 4 and 1 (each within the scatter of the next); then compounds 2 and 3 (each within the scatter of the next).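

On the carbonyl carbon bound to the amide-type nitrogen, the aryl group is far from a neutral end of the molecule: in this assay there is a number 81.6 percentage points lower from compound 3 to compound 4 (beyond the scatter), a large step with the rest of the structure unchanged, including the amino on the other carbonyl carbon. Within the data shown here, the amino group therefore does not secure a high number by itself, and the earlier a number 79.4 percentage points higher from compound 1 to compound 3 (beyond the scatter) is so far seen only with 4-(trifluoromethyl)phenyl in place. Nothing on hand accounts for the size of this step.

The step replaces both the substituent and its ring position at once, so the contribution of each cannot be separated. A plain phenyl or a methoxyphenyl on the same carbonyl carbon would show whether high inhibition is confined to 4-(trifluoromethyl)phenyl.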